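The compounds below may be only part of what the source reports. "The series", "measured", "known", "first", "only" and "open" are said of these compounds alone.

Measured in a toxicity assay on MT2 cells (Homo sapiens) for cytotoxicity, read by XTT assay, with a stated time of 4 days; a higher number here means that more compound is tolerated, a lower number that less compound is tolerated:
- Compound 1 `Cc1cc(CCOc2ccc(-c3c(C)nc(C)c([C@H](OC(C)(C)C)C(=O)O)c3N3CCC(C)(C)CC3)cc2)ccc1F` gives >= 33500 nM as a limit
- Compound 2 `Cc1nc(C)c([C@H](OC(C)(C)C)C(=O)O)c(N2CCC(C)(C)CC2)c1-c1ccc(OCCc2cc(F)ccc2F)cc1` gives >= 33500 nM as a limit
- Compound 3 `Cc1nc(C)c([C@H](OC(C)(C)C)C(=O)O)c(N2CCC(C)(C)CC2)c1-c1ccc(OCCc2ccccn2)cc1` gives >= 25000 nM as a limit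

Compound 3 stands at >= 25000 nM and this is a limit, not a number. The other two compounds also give only limits, so the three cannot be placed in any order. None of them has a measured half-maximal cytotoxic concentration.

The next compound is compound 4 `Cc1nc(C)c(CCOc2ccc(-c3c(C)nc(C)c([C@H](OC(C)(C)C)C(=O)O)c3N3CCC(C)(C)CC3)cc2)s1`, which differs from compound 3 only in the group on the ethoxy chain: 2,4-dimethyl-1,3-thiazol-5-yl in place of pyridin-2-yl, on a saturated chain carbon, two bonds along the chain from an oxygen on an aromatic ring (2,4-dimethyl-1,3-thiazol-5-yl in place of pyridin-2-yl on a saturated chain carbon, two bonds along the chain from an oxygen on an aromatic ring).

Within the data shown here, three measured steps bear on this change, since all of them swap the group at that same chain carbon: a step that the two limits leave unreadable from compound 1 to compound 2 and a step that the two limits leave unreadable from compound 1 to compound 3 and a step that the two limits leave unreadable from compound 2 to compound 3 are the whole of the evidence. None of them has a readable size, so they offer no sign that this position moves the result. No step beyond the scatter is therefore expected in this assay and no direction can be given. The expected change is a step that the limit leaves unreadable from compound 3 to compound 4 and this is only a loose estimate. Compound 4 may well be reported only as a limit too.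

Compound 4 is expected at 30000 nM with an estimated range from 12000 nM to 60000 nM as its upper end.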

Compound 4, half-maximal cytotoxic concentration: >= 25000 nM
Compound 4 was reported as a limit; the forecaster's own chance of this, stated with the estimate: 80%; the middle value lies beyond the limit too.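

In this assay compound 4 gives >= 25000 nM, which is a limit and not a number. Its steps from compound 1, compound 2 and compound 3 therefore cannot be read, as the values rest on limits: the limit of >= 25000 nM in this assay, at which 2 of the 4 values shown sit.

The compounds shown leave open the actual half-maximal cytotoxic concentration of each, and whether changing the group at this chain carbon alters it at all.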